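The source may hold more compounds than are shown below. What is called first, only, known or untested is meant among the compounds shown, and "the series" means these compounds.

Working notes on the series. Compound 1 `CC(C)/N=C(\NC1=NC(=O)CN1c1ccc(Cl)c(Cl)c1)Nc1ccc(Cl)c(Cl)c1` gives 0.654 h in an in vivo ADME assay on the whole organism for metabolic stability, with Homo sapiens as the target, read by LC-MS, at a dose of 160 mg/kg by the oral route; a lower number here means that the compound disappears faster, a higher number that the compound lasts longer. Compound 3 `CN1CC(=O)N=C1NC(=N)Nc1ccc(Cl)c(Cl)c1` returns only a limit in this assay, > 1 h, and so sits at the limit of > 1 h in this assay, at which 1 of the 3 values shown sits. Compound 2 `CC(C)(C)OC(=O)/N=C(\NC1=NC(=O)CN1C(C)(C)C)Nc1ccc(Cl)c(Cl)c1` likewise returns only a limit in this assay, < 0.167 h. On the numbers shown, compound 2 therefore stands at the limit of < 0.167 h in this assay, at which 1 of the 3 values shown sits, the shortest-lived position in the set, with compound 1 giving the only number between the two limits. Compound 4 `CN1CC(=O)N=C1N/C(=N\C(=O)OC(C)(C)C)Nc1ccc(Cl)c(Cl)c1` differs from compound 2 by methyl in place of tert-butyl on an amine nitrogen in a ring, the carbamate kept. Among the compounds with values here, no measured step of this kind exists in the set; compound 3 carries the methyl but lacks the carbamate. The step is expected to run toward a longer half-life, an at least 2.3-fold higher number from compound 2 to compound 4 (0.37 log units; beyond the scatter), beyond the scatter. Compound 4 is expected to give about 0.4 h, between 0.12 h and 1.3 h.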

Compound 4, half-life: < 0.167 h
Compound 4 was reported as a limit (the forecaster's own chance of this, stated with the estimate: 40%); at least 2.3-fold (0.37 log units) between middle value and limit.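

Within the data shown here, compound 2 and compound 4 both return only limits, so no step between them can be read. Still open, on these data alone, is how far the half-life moves when methyl replaces tert-butyl on an amine nitrogen in a ring.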